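A few compounds are considered here, and "the series" means these few. Any claim that something is new, unique, unknown or untested is made for them only; others in the source may bear on it.

Of the compounds shown here, three built on one shared core have been measured in a functional assay on HeLa cells (Homo sapiens) for antiproliferative activity, read by CCK-8 assay, with a stated time of 72 h, tested at 8 uM; a lower number here means a weaker effect, a higher number a stronger effect of the compound at the concentration tested. Compound 1 `Nc1ccccc1NC(=O)c1ccc(CSC(=S)N2CCN(Cc3ccccn3)CC2)cc1` gives 61.4%. Compound 3 `Nc1ccccc1NC(=O)c1ccc(CSC(=S)N2CCc3cc(Cl)ccc32)cc1` gives 65.1%, a reading within the usual scatter of that of compound 1, so neither can be called stronger than the other. Compound 2 `Nc1ccccc1NC(=O)c1ccc(CSC(=S)N2CCN(C(c3ccccc3)c3ccccc3)CC2)cc1` gives 13.8%, a reading far below that of compound 1 and well beyond the scatter. Compound 1 thus stands with compound 3 among the higher readings, while compound 2 stands apart as the weaker one.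

Compound 4 `Nc1ccccc1NC(=O)c1ccc(CSC(=S)N2CCN(Cc3cccnc3)CC2)cc1` has not yet been measured. It differs from compound 1 in a single place: pyridin-3-yl in place of pyridin-2-yl on a saturated chain carbon bound to an amine nitrogen in a ring. Going by the values given here, no pair of measured compounds shows a change of this kind, so the data give no direct guide. The group that leaves and the group that enters match in everything counted. The expected step is a number 3.4 percentage points lower from compound 1 to compound 4 (within the scatter), none beyond the scatter. Compound 4 is estimated to give 58%, within a range from 40% to 74%.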

Compound 4, a percentage reported as inhibition, at one concentration (the size of the read-out at that concentration, not a potency): 78%
Compound 4: middle estimate off by 20 percentage points, on the low side; measured number above the stated range.
By their numbers in this assay, from the lowest: compound 2; then compounds 1 and 3 (each within the scatter of the next); then compound 4.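

In this assay, pyridin-3-yl in place of pyridin-2-yl gives a number 16.6 percentage points higher from compound 1 to compound 4 (beyond the scatter), a modest step. The two groups match in everything counted and differ only in how the same atoms are joined, so at this place the reading responds to the arrangement of the ring alone, not to its size or composition. Going by these compounds alone, this is the first change in a single place that can be read, though nothing measured here explains why the arrangement matters.

Going by these compounds, it remains open whether the ring nitrogen is needed at all, which a benzyl group at this place would test. A (pyridin-3-yl)ethyl group, with its longer chain, would show whether the reading of compound 4 survives a change in the link to the ring.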